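The source may report more compounds than this note shows. Statements on the series, on what has been measured and on what is new or still open speak of the compounds shown alone.

Measured in a functional assay on SEM cells (Homo sapiens) for cytotoxicity, with a stated time of 72 h; on this read-out higher numbers stand for an effect only at larger amounts of compound and lower numbers for an effect already at smaller amounts:
- compound 1 `COc1ccc(/C=C/[C@@](C)(/C=C/c2ccc(O)c(/C=C/C#N)c2)CCC=C(C)C)cc1`: 4540 nM
- compound 2 `COc1ccc(/C=C/[C@@](C)(/C=C/c2ccc(O)c(/C=C/C(C)=O)c2)CCC=C(C)C)cc1`: 8670 nM
- compound 3 `COc1ccc(/C=C/[C@@](C)(/C=C/c2ccc(O)c(/C=C/C(=O)c3ccccc3)c2)CCC=C(C)C)cc1`: not yet measured

Compound 2, at 8670 nM, lies within the usual scatter of compound 1, so the two numbers do not separate. The next change is phenyl in place of methyl on a carbonyl carbon. Among the measured compounds shown here, one measured step bears on it: a 1.9-fold higher number from compound 1 to compound 2 (0.28 log units; within the scatter), acetyl in place of cyano on a double-bonded chain carbon. For the measured compounds named here, that step stays within the scatter, but it is a single pair, and no measured compound carries the phenyl group. The size of this larger change therefore remains uncertain. In this assay, no step beyond the scatter is expected, and the range is kept wide on both sides. The estimated step is a 1.2-fold lower number from compound 2 to compound 3 (0.09 log units; within the scatter). For compound 3 the expected value is 7000 nM, with an estimated range of 2500 nM to 18000 nM.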

Compound 3, half-maximal effective concentration: 36600 nM
The estimate for compound 3 lay 5.2-fold (0.72 log units) below the measured number; the measured number lies above the stated range.
By their numbers in this assay, from the lowest: compounds 1 and 2 (each within the scatter of the next); then compound 3.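

In this assay, among the compounds shown here, phenyl in place of methyl on a carbonyl carbon gives the first step in this short series that lies beyond the scatter, with a 4.2-fold higher number from compound 2 to compound 3 (0.63 log units; beyond the scatter). Benzoyl in place of cyano on a double-bonded chain carbon likewise gives an 8.1-fold higher number from compound 1 to compound 3 (0.91 log units; beyond the scatter), so this position does respond to a change, and compound 3 stands apart from compound 1 and compound 2, which do not separate. No measurement at hand explains these steps.

Still open, as far as these compounds go, is whether the higher number goes with the aromatic ring itself or simply with added carbon, a question that an ethyl or cyclohexyl group on the same carbonyl carbon would address. Also open, from the compounds shown here alone, is how a benzoyl ring carrying an amine or a carboxylic acid would read in this assay.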